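Sulfonyl urea series: sulfonamide replacing the aryl sulfonate

A few compounds are considered here, and "the series" means these few. Any claim that something is new, unique, unknown or untested is made for them only; others in the source may bear on it.

Compound 3 `O=C(NCCCCl)Nc1ccc(S(=O)(=O)Oc2ccc(O)cc2)cc1` gives the highest number of the three measured here: in a functional assay on HT-29 cells (Homo sapiens) for cytotoxicity, read by sulforhodamine B assay, with a stated time of 48 h (a lower number here means a stronger inhibitor, a higher number a weaker inhibitor), compound 3 gives 50000 nM. Compound 1 `Cc1ccccc1OS(=O)(=O)c1ccc(NC(=O)NCCCCl)cc1` gives 26000 nM and compound 2 `CCCc1ccccc1OS(=O)(=O)c1ccc(NC(=O)NCCCCl)cc1` gives 13000 nM; the step of a 1.9-fold higher number from compound 1 to compound 3 (0.28 log units; within the scatter) stays within the scatter, whereas a 3.8-fold higher number from compound 2 to compound 3 (0.59 log units; beyond the scatter) goes beyond it. Compound 4 `Cc1ccccc1NS(=O)(=O)c1ccc(NC(=O)NCCCCl)cc1` differs from compound 3 by (2-methylphenyl)amino in place of 4-hydroxyphenoxy on a sulfonyl sulfur. Going by the values given here, the part of this change concerning the aryl group is covered by the reverse of a 1.9-fold higher number from compound 1 to compound 3 (0.28 log units; within the scatter); the change from an oxygen link to a nitrogen link at the sulfonyl sulfur is covered by no measured step. The expected step is therefore modest, towards a lower number, a 2.5-fold lower number from compound 3 to compound 4 (0.40 log units; beyond the scatter), and compound 4 is estimated at 20000 nM with a range from 7000 nM to 60000 nM.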

Compound 4, half-maximal inhibitory concentration: 64000 nM
For compound 4 the middle estimate is 3.2-fold (0.51 log units) below the measured one; measured number above the stated range.
By their numbers in this assay, from the lowest: compounds 2, 1, 3 and 4 (each within the scatter of the next, the first and the last beyond it).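

With the 2-methylphenyl group held constant, the nitrogen link on the sulfonyl sulfur gives a 2.5-fold higher number from compound 1 to compound 4 (0.39 log units; beyond the scatter) in this assay and so isolates the linking atom, with the change running towards a weaker inhibitor. The step of a 1.3-fold higher number from compound 3 to compound 4 (0.11 log units; within the scatter) shows no separation from the 4-hydroxyphenoxy compound, so the nitrogen link brings no gain over either oxygen-linked comparator. No evidence available here explains this result. Still open, from the compounds shown here alone, is whether a propyl group on the aryl ring lowers the number with the nitrogen link as well, and whether a methyl group on the sulfonamide nitrogen changes it.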